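A Pyridine Swap on a Weak Antiproliferative Compound

The source may hold more compounds than are shown below. What is called first, only, known or untested is meant among the compounds shown, and "the series" means these compounds.

Compound 1 `CC/C=C/C(=O)Nc1cccc(Oc2nc(Nc3cccc(OC)c3)nc3c2CSCC3)c1`: 27200 nM
Compound 2 `COc1cccc(Nc2nc3c(c(Oc4cccc(NC(=O)C=C(C)C)c4)n2)CSCC3)c1`: 19100 nM
Compound 3 `COc1cccc(Nc2nc3c(c(Oc4cccc(NC(=O)/C=C/C(C)C)c4)n2)CSCC3)c1`: > 50000 nM

In a functional assay on HeLa cells (Homo sapiens) for antiproliferative activity, read by MTT assay, with a stated time of 72 h (a lower number here means a stronger inhibitor, a higher number a weaker inhibitor), compound 1 gives 27200 nM. Among the measured compounds shown here, the only other exact number lies close to it, a 1.4-fold lower number from compound 1 to compound 2 (0.15 log units; within the scatter). Compound 3 gives only a limit, > 50000 nM. Measured against that limit, the series shows an at least 1.8-fold higher number from compound 1 to compound 3 (0.26 log units; that floor lies within the scatter), and also an at least 2.6-fold higher number from compound 2 to compound 3 (0.41 log units; beyond the scatter).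

Compound 4 `CC/C=C/C(=O)Nc1cccc(Oc2nc(Nc3ccc(OC)nc3)nc3c2CSCC3)c1` keeps the amide end of compound 1 and changes the other side of the core: 6-methoxypyridin-3-yl in place of 3-methoxyphenyl on a nitrogen on an aromatic ring. In words, 6-methoxypyridin-3-yl stands in place of 3-methoxyphenyl on a nitrogen on an aromatic ring. For the measured compounds named here, none of the measured steps touches that place, since all three alter the group on the carbonyl carbon. They therefore bear on the swap only indirectly, as a guide to how far values move in this small series. Going by the values given here, no measured compound shows what this exchange does, so no direction can be drawn from the data, and no step beyond the scatter is expected in this assay.

The estimated change is a 1.0-fold higher number from compound 1 to compound 4 (0.01 log units; within the scatter). For compound 4 the expected value is 28000 nM, with an estimated range of 11000 nM to 50000 nM.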

Compound 4, half-maximal inhibitory concentration: 31200 nM
Estimate against measurement, compound 4: 1.1-fold (0.05 log units) below, and the stated range covers the measured number.
By their numbers in this assay, from the lowest: compounds 2, 1 and 4 (each within the scatter of the next). At a limit, above all of these: compound 3.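

The exchange of 3-methoxyphenyl for 6-methoxypyridin-3-yl is the only change shown on the nitrogen on an aromatic ring, whereas the earlier steps all altered the group on the carbonyl carbon. In this assay, it gives a 1.1-fold higher number from compound 1 to compound 4 (0.06 log units; within the scatter), so a ring with 1 hetero atom and a count of 2 hydrogen-bond acceptors in place of 1 leaves compound 4 indistinguishable from compound 1. This place therefore tolerates this one exchange without a readable change in the number, although the comparison is made among weak compounds, one of which reaches the top of the measurable range: the limit of > 50000 nM in this assay, at which 1 of the 4 values shown sits.

The compounds shown leave open whether 6-methoxypyridin-3-yl would read the same alongside the 2-methylprop-1-en-1-yl group of compound 2, or on a compound with a much lower number. They also leave open whether an amine such as dimethylamino or morpholine in place of the methoxy group, or a pyrimidine ring in place of the pyridine, would move the number beyond the scatter at this place.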